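The compounds below may be only part of what the source reports. "The series", "measured", "known", "first", "only" and "open" are said of these compounds alone.

Compound 2 `CCCCCCCCCCCCCCCCCCNC(=O)[C@@H](NC(=O)c1cc2ccccc2[nH]1)[C@@H](C)O` gives 23600 nM in a functional assay on SW-620 cells (Homo sapiens) for cytotoxicity, read by MTT assay, with a stated time of 48 h (on this read-out lower numbers stand for stronger inhibition and higher numbers for weaker inhibition), and it stands as the lower of the two numbers recorded so far. Compound 1 `CCCCCCCCCCCCCCNC(=O)[C@@H](NC(=O)/C=C/c1ccccc1)[C@@H](C)O` gives 200000 nM in this assay, a weaker result well beyond the scatter. The two measured compounds differ in two places at once, the length of the alkyl chain on the amide nitrogen and the acyl group on the amino nitrogen, so neither change can be read on its own from what has been measured.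

Compound 3 `CCCCCCCCCCCCCCCCCCNC(=O)[C@@H](NC(=O)/C=C/c1ccccc1)[C@@H](C)O` keeps the octadecyl chain of compound 2 and takes the acyl group of compound 1: the change is 2-phenylethenyl in place of 1H-indol-2-yl on a carbonyl carbon. Since compound 1 carries this same group and is weaker, the expected step is a 3.4-fold higher number from compound 2 to compound 3 (0.53 log units; beyond the scatter), toward weaker inhibition but by less than the gap between the two measured compounds. Compound 3 is therefore estimated to give 80000 nM in this assay, with a range from 25000 nM to 250000 nM.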

Compound 3, half-maximal inhibitory concentration: 200000 nM
Estimate against measurement, compound 3: 2.5-fold (0.40 log units) below, and the stated range covers the measured number.
By their numbers in this assay, from the lowest: compound 2; then compounds 1 and 3 (each within the scatter of the next).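

In this assay, with the octadecyl chain held fixed, 2-phenylethenyl in place of 1H-indol-2-yl on a carbonyl carbon gives an 8.5-fold higher number from compound 2 to compound 3 (0.93 log units; beyond the scatter) and thus shows the effect of the acyl change alone. The chain can now also be read alone: butyl in place of hydrogen on a saturated chain carbon gives no change at the digits printed from compound 1 to compound 3 (within the scatter) and so, with 2-phenylethenyl on the carbonyl carbon, the longer chain of compound 3 shows no gain over compound 1. No measurement at hand accounts for either step.

Going by these compounds, whether the 1H-indol-2-yl group would keep its advantage on the shorter chain of compound 1 remains open. So does the outcome with a carboxylic acid or an amine on the phenyl ring of 2-phenylethenyl, or with a chain longer than octadecyl on the amide nitrogen.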